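A few compounds are considered here, and "the series" means these few. Any claim that something is new, unique, unknown or untested is made for them only; others in the source may bear on it.

Three compounds share one core and differ only in the group attached to the carbonyl carbon. Compound 1 `Cc1ccc(C(=O)N2N=C(c3cc4ccccc4oc3=O)CC2c2ccccc2)cc1` gives 13200 nM in a functional assay on PC-3 cells (Homo sapiens) for cytotoxicity, read by MTT assay, with a stated time of 48 h; on this read-out higher numbers stand for weaker inhibition and lower numbers for stronger inhibition. Compound 2 `CCNCC(=O)N1N=C(c2cc3ccccc3oc2=O)CC1c1ccccc1` gives 5580 nM. Compound 3 `CC1CCCCN1CC(=O)N1N=C(c2cc3ccccc3oc2=O)CC1c1ccccc1` gives 36300 nM, the highest of the three numbers and so the weakest inhibition here. The measured steps are a 2.4-fold lower number from compound 1 to compound 2 (0.37 log units; beyond the scatter), a 2.8-fold higher number from compound 1 to compound 3 (0.44 log units; beyond the scatter) and a 6.5-fold higher number from compound 2 to compound 3 (0.81 log units; beyond the scatter), all modest. Compound 4 `CC1CC(C)CN(CC(=O)N2N=C(c3cc4ccccc4oc3=O)CC2c2ccccc2)C1` differs from compound 3 by 3,5-dimethylpiperidin-1-yl in place of 2-methylpiperidin-1-yl on a saturated chain carbon bound to a carbonyl carbon. For the measured compounds named here, only the step from compound 2 to compound 3 touched this place, and it was modest; a second ring of this kind has not been tested, so there is no firm lead. Compound 4 is therefore estimated at 36000 nM, within 12000 nM to 110000 nM. The expected step is a 1.0-fold lower number from compound 3 to compound 4 (0.00 log units; within the scatter), not beyond the scatter.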

Compound 4, half-maximal inhibitory concentration: "not active" (no number reported)
Compound 4: no number reported, and the estimate cannot be compared.
By their numbers in this assay, from the lowest: compound 2; then compound 1; then compound 3.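

For the compounds shown here, compound 4 is reported as "not active" with no number, so no step from compound 3 to compound 4 can be read. Nothing given here explains this result. Going by these compounds, how far 3,5-dimethylpiperidin-1-yl shifts the number in this assay remains open.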